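Chain Shortening and Cytotoxic Inhibition in the Triazole Series

A few compounds are considered here, and "the series" means these few. Any claim that something is new, unique, unknown or untested is made for them only; others in the source may bear on it.

Compound 2 `CCCCCCc1cn(C(c2ccccc2)c2cc3cc(Br)ccc3nc2OC)nn1` gives 6.08% in an ADME assay on PANC-1 cells (Homo sapiens) for cytotoxicity, read by sulforhodamine B assay, with a stated time of 48 h, tested at 10 uM (on this read-out lower numbers stand for less inhibition and higher numbers for more inhibition at the one concentration tested (going by the name of the read-out)), the lowest of the three numbers, beneath compound 1 `CCCCCCCc1cn(C(c2ccccc2)c2cc3cc(Br)ccc3nc2OC)nn1` with 16.6% and compound 3 `COc1nc2ccc(Br)cc2cc1C(c1ccccc1)n1cc(-c2ccccc2)nn1` with 30.1%. Compound 4 `CCCCc1cn(C(c2ccccc2)c2cc3cc(Br)ccc3nc2OC)nn1` is not yet measured; it differs from compound 2 by hydrogen in place of ethyl on a saturated chain carbon, four bonds along the chain from an aromatic carbon. The step that bears on this is a number 10.5 percentage points lower from compound 1 to compound 2 (beyond the scatter), a shortening of the same chain. The aryl replacements a number 13.5 percentage points higher from compound 1 to compound 3 (beyond the scatter) and a number 24 percentage points higher from compound 2 to compound 3 (beyond the scatter) run the other way but do not touch chain length. A further cut of the chain is therefore expected to give a step of a number 3.1 percentage points lower from compound 2 to compound 4 (within the scatter), within or just beyond the scatter, downward if anything. Compound 4 is estimated at 3%, with a range of -7% to 13%.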

Compound 4, a percentage reported as inhibition, at one concentration (the size of the read-out at that concentration, not a potency): 5.46%
Compound 4: the middle estimate sits 2.5 percentage points below what was measured, and the stated range covers the measured number.
By their numbers in this assay, from the lowest: compounds 4 and 2 (each within the scatter of the next); then compound 1; then compound 3.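

Hydrogen in place of ethyl on a saturated chain carbon, four bonds along the chain from an aromatic carbon, gives a number 0.6 percentage points lower from compound 2 to compound 4 (within the scatter) in this assay and so does not separate the hexyl and butyl chains. The heptyl chain stays apart from butyl, with a number 11.1 percentage points lower from compound 1 to compound 4 (beyond the scatter) on the same read-out, and the aryl group stays apart too, with a number 24.6 percentage points lower from compound 3 to compound 4 (beyond the scatter) for butyl in place of phenyl on the aromatic carbon. No measurement on hand accounts for these numbers. Still open, on these data alone, is how a longer chain such as octyl would read, and whether an amine or a carboxylic acid at the chain end would change the number.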